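Weak antiproliferative results and a smaller substituent

The source may report more compounds than this note shows. Statements on the series, on what has been measured and on what is new or still open speak of the compounds shown alone.

Measured in a functional assay on KYSE-410 cells (Homo sapiens) for antiproliferative activity, read by MTT assay, with a stated time of 72 h; on this read-out higher numbers stand for weaker inhibition and lower numbers for stronger inhibition:
Compound 1 `O=C(Nc1ccc(C(F)(F)F)cc1)c1cc(=O)[nH]c2cc(Br)ccc12`: > 20000 nM, a limit
Compound 2 `COc1ccc2c(C(=O)Nc3cc(F)cc(F)c3)cc(=O)[nH]c2c1`: > 20000 nM, a limit
Compound 3 `COc1ccc(-c2ccc3c(C(=O)Nc4cccc(F)c4)cc(=O)[nH]c3c2)cc1`: 18000 nM

Going by the values given here, compound 3 gives the only true number in this assay, at 18000 nM. Compound 1 and compound 2 mark (the limit of > 20000 nM in this assay, at which 2 of the 3 values shown sit).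

Compound 4 `O=C(Nc1cccc(F)c1)c1cc(=O)[nH]c2cc(C3CC3)ccc12` carries cyclopropyl in place of 4-methoxyphenyl on an aromatic carbon, meta to a fused ring and para to a fused ring (cyclopropyl in place of 4-methoxyphenyl on an aromatic carbon). Among the compounds with values here, no measured pair shows this change. In this assay, no step beyond the scatter is expected, and any drift would be towards weaker inhibition. The expected step is a 1.1-fold higher number from compound 3 to compound 4 (0.05 log units; within the scatter). For compound 4 the estimate is 20000 nM, with an expected range of 8000 nM to 40000 nM.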

Compound 4, half-maximal inhibitory concentration: > 20000 nM
Compound 4 was reported as a limit; the forecaster's own chance of this, stated with the estimate: 55%; the middle value lies on the limit itself.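

Cyclopropyl in place of 4-methoxyphenyl on this aromatic carbon gives, in this assay, an at least 1.1-fold higher number from compound 3 to compound 4 (0.04 log units; that floor lies within the scatter). Going by these compounds alone, this is the first pair at this position that can be read, and the value for compound 4 is a limit, not a number, so only that floor is known. The one true number in the set is not joined by a second: the limit of > 20000 nM in this assay, at which 3 of the 4 values shown sit.

The compounds shown leave open whether an amine, a carboxylic acid or a longer chain on this aromatic carbon would give a true number in this assay.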